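The source may report more compounds than this note shows. Statements on the series, on what has been measured and on what is new or still open speak of the compounds shown alone.

Compound 1 `N[C@H]1CC[C@H](Nc2c(C(=O)NCc3ccc(Cl)cc3)nc(Br)c3cccnc23)CC1`, compound 2 `C[C@@H](Nc1c(C(=O)NCc2ccc(F)cc2)nc(Br)c2cccnc12)c1ccccc1` and compound 3 `CS(=O)(=O)NCCCN(c1nc(C(=O)NCc2ccc(F)cc2)c(O)c2ncccc12)S(C)(=O)=O` were each tested in a functional assay on MDA-MB-435 cells (Homo sapiens) for cytotoxicity, read by MTT assay, with a stated time of 72 h; a higher number here means a weaker inhibitor, a lower number a stronger inhibitor. Compound 1 gives a measured number in this assay, namely 1000 nM. For compound 2 the reading in this assay is only a limit, > 20000 nM. Compound 3 likewise returns only a limit in this assay, > 20000 nM. Compound 2 therefore stands at the limit of > 20000 nM in this assay, at which 2 of the 3 values shown sit, with no number of its own to compare against. Compound 4 `O=C(NCc1ccc(F)cc1)c1nc(Br)c2cccnc2c1NCCO` has not yet been tested in this assay. It differs from compound 2 in a single place: 2-hydroxyethyl in place of 1-phenylethyl on a nitrogen on an aromatic ring. Among the compounds with values here, no step between two measured compounds that differ in only one place is available here, so the size of this change cannot be read from a neighbouring pair. Still, the step from compound 2 to compound 4 is expected to be an at least 2.0-fold lower number from compound 2 to compound 4 (0.30 log units; that floor lies within the scatter), a move toward stronger inhibition in this assay that may not reach beyond the scatter. Compound 4 is estimated to give about 10000 nM in this assay, within a range from 2000 nM to 40000 nM.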

Compound 4, half-maximal inhibitory concentration: > 20000 nM
Compound 4: a limit, no number; the forecaster's own chance of this, stated with the estimate: 50%; middle value at least 2.0-fold (0.30 log units) from the limit.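

Within the data shown here, compound 2 and compound 4 both return only a limit, so the change from 1-phenylethyl to 2-hydroxyethyl gives no step that can be read: the limit of > 20000 nM in this assay, at which 3 of the 4 values shown sit. The compounds shown leave open whether these two groups on that nitrogen differ at all in this assay.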